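The compounds below may be only part of what the source reports. "The series", "measured", "known", "first", "only" and "open" are said of these compounds alone.

For the measured compounds named here, compound 3 `Cc1nc(-c2cccc(Cl)c2)sc1COc1ccc2c(c1)OCC2CC(=O)O` is the only member of this small set with a number in a functional assay on CHO cells for agonist activity at Free fatty acid receptor 1 (Homo sapiens), read by FLIPR and calcium flux; a higher number here means that more compound is needed for the effect, a lower number that less compound is needed. In this assay compound 3 gives 138 nM. Compound 1 `Cc1nc(-c2ccc(Cl)s2)sc1COc1ccc2c(c1)OCC2CC(=O)O` appears without a result: in this assay compound 1 gives "not determined" (no result reported). Compound 2 `Cc1ccccc1-c1nc(C)c(COc2ccc3c(c2)OCC3CC(=O)O)s1` likewise appears without a result: in this assay compound 2 gives "not determined" (no result reported). Compound 4 `Cc1nc(-c2ccc(F)cc2)sc1COc1ccc2c(c1)OCC2CC(=O)O` differs from compound 3 in one place: 4-fluorophenyl in place of 3-chlorophenyl on an aromatic carbon. Going by the values given here, no step between two measured compounds is available to calibrate this change, so the expectation rests on compound 3 alone. The step of a 1.8-fold higher number from compound 3 to compound 4 (0.26 log units; within the scatter) is expected to be small, pointing toward more compound being needed, and it may well stay within the usual scatter. Starting from the value of compound 3 in this assay, compound 4 is therefore estimated at 250 nM, with a range from 80 nM to 800 nM.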

Compound 4, half-maximal effective concentration: 48.7 nM
Compound 4: middle estimate off by 5.1-fold (0.71 log units), on the high side; the whole stated range lies above it.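

Replacing 3-chlorophenyl with 4-fluorophenyl on this aromatic carbon of the five-membered ring gives a 2.8-fold lower number from compound 3 to compound 4 (0.45 log units; beyond the scatter) in this assay. This first measured step in the set shows that the result at this position depends on the substituted phenyl group it carries, and here less compound is needed. Nothing available bears on why the number falls.

On these data alone, because both the halogen and its place on the phenyl ring change, their shares of the step remain open. As far as these compounds go, how a 4-chlorophenyl or 3-fluorophenyl group would read also remains open.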